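The source may report more compounds than this note shows. Statements on the series, on what has been measured and on what is new or still open speak of the compounds shown alone.

Working notes on the series. For the measured compounds named here, compound 1 `COCCNCc1c(-c2nnc(SC(C)C)n2-c2ccccc2)n(C)c2ccccc12` is the most polar of the three compounds so far in a physicochemical assay for lipophilicity (a higher number here means a more lipophilic compound, a lower number a more polar compound), where compound 1 gives 4.36. Compound 3 `COCCNCc1c(-c2nnc(SC(C)C)n2-c2ccccc2)n(C)c2ccc(F)cc12` sits close to it: compound 3 gives 4.52, and the step of a number 0.16 log units higher from compound 1 to compound 3 (within the scatter) is within the scatter. Compound 2 `COc1cccc(CNCc2c(-c3nnc(SC(C)C)n3-c3ccccc3)n(C)c3ccc(F)cc23)c1` is the outlier; compound 2 gives 6.42, and the step of a number 1.90 log units lower from compound 2 to compound 3 (beyond the scatter) shows how strongly the substituent on the amine nitrogen sets this assay.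

Compound 4 `CC(C)Sc1nnc(-c2c(CNc3cnccn3)c3ccccc3n2C)n1-c1ccccc1` differs from compound 1 by pyrazin-2-yl in place of 2-methoxyethyl on an amine nitrogen. The change sits at the same place as the step from compound 2 to compound 3, but exchanges the chain for a smaller aromatic ring with two hetero atoms rather than a methoxyphenyl, so a much smaller rise is expected, a number 0.44 log units higher from compound 1 to compound 4 (beyond the scatter). Compound 4 is therefore estimated at 4.8, with a range from 4.2 to 5.5.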

Compound 4, partition coefficient: 4.22
Estimate against measurement, compound 4: 0.58 log units above, within the range that was stated.
By their numbers in this assay, from the lowest: compounds 4, 1 and 3 (each within the scatter of the next); then compound 2.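

On the amine nitrogen, pyrazin-2-yl in place of 2-methoxyethyl gives a step within the scatter in this assay, a number 0.14 log units lower from compound 1 to compound 4 (within the scatter). An aromatic ring entering this part of the molecule therefore does not by itself bring a change of the size of a number 1.90 log units lower from compound 2 to compound 3 (beyond the scatter). Nothing measured here bears on the reason for this difference.

Open, on these data alone, is how a phenyl or a pyridin-2-yl group on the same amine nitrogen would read in this assay. Also open, as far as these compounds go, is whether the fluoro step stays within the scatter with pyrazin-2-yl in place.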